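The source may report more compounds than this note shows. Statements on the series, on what has been measured and on what is new or still open speak of the compounds shown alone.

In an assay on isolated protein for binding affinity to Alpha-1D adrenergic receptor (Rattus norvegicus), read by radioligand binding (a lower number here means a stronger inhibitor, a higher number a weaker inhibitor), compound 3 `CS(=O)(=O)Nc1cccc2c1CCCC2C1=NCCN1` gives 4270 nM, the higher of the two numbers reported so far. Compound 2 `CS(=O)(=O)Nc1c(O)ccc2c1CCCC2c1c[nH]cn1` gives 1260 nM, which is the nearest value, and the gap between the two lies beyond the usual scatter. Compound 1 `CCS(=O)(=O)Nc1cccc2c1CCCC2(O)c1c[nH]cn1` is reported only as a limit of the assay, < 10000 nM, and not as a number (the limit of < 10000 nM in this assay, at which 1 of the 3 values shown sits). Compound 4 `Cn1cnc(C2CCCc3c(NS(C)(=O)=O)cccc32)c1` has not yet been measured; it differs from compound 3 in one place: a group of 6 heavy atoms (4 carbon, 2 nitrogen; one five-membered aromatic ring with 2 hetero atoms) in place of a group of 5 heavy atoms (3 carbon, 2 nitrogen; one five-membered non-aromatic ring with 2 hetero atoms), on a saturated ring carbon. For the measured compounds named here, no pair of measured compounds differs in just this way, so the size of the step is uncertain; a modest shift, possibly towards a weaker binder, is expected, and for compound 4 the expected step is a 1.4-fold higher number from compound 3 to compound 4 (0.15 log units; within the scatter). Compound 4 is therefore expected to give about 6000 nM, within a range from 1500 nM to 20000 nM.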

Compound 4, inhibition constant: 1050 nM
Compound 4: middle estimate off by 5.7-fold (0.76 log units), on the high side; measured number below the stated range.
By their numbers in this assay, from the lowest: compounds 4 and 2 (each within the scatter of the next); then compound 3.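

At this saturated ring carbon, replacing the non-aromatic five-membered ring with 1-methyl-1H-imidazol-4-yl gives a 4.1-fold lower number from compound 3 to compound 4 (0.61 log units; beyond the scatter) in this assay. The entering group has no hydrogen-bond donor and the leaving group has one, so for this pair a donor on this group is not needed for the lower number. An aromatic ring is also accepted at this carbon.

As far as these compounds go, what an open-chain amine or a longer chain on the imidazole nitrogen would do at this carbon remains open. No measurement shown explains this step.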